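The source may report more compounds than this note shows. Statements on the series, on what has been measured and on what is new or still open speak of the compounds shown alone.

Compound 1, `O=C(/C=C/c1ccncc1)c1cccc(C(F)(F)F)c1`, gives 41000 nM in a functional assay with Rattus norvegicus as the target; on this read-out lower numbers stand for stronger inhibition and higher numbers for weaker inhibition.
Compound 2, `CC(C)(C)c1ccc(C(=O)/C=C/c2ccncc2)cc1`, gives 47000 nM in this assay.
Compound 3, `O=C(C#Cc1ccncc1)c1ccccc1`, gives 16000 nM in this assay.

Among these three, compound 2 sits at the weak end of the range. Its number and that of compound 1 lie within the scatter of each other, so no order can be drawn between them; compound 3 alone gives a number that is lower by more than the scatter, and compound 3 also differs from the other two in more than one place, so nothing about a single change can be read from it.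

The step to compound 4, `O=C(/C=C/c1ccncc1)c1ccc(Cl)cc1`, changes compound 2 in one place: chloro in place of tert-butyl on an aromatic carbon. Going by the values given here, no measured pair in this set shows what that exchange does on its own, so the expectation rests only on the values at hand. Compound 4 is expected to stay close to compound 2, with at most a modest move toward lower numbers, a 1.6-fold lower number from compound 2 to compound 4 (0.19 log units; within the scatter), a step that may well fall within the scatter. The estimate for compound 4 in this assay is 30000 nM, between 10000 nM and 90000 nM.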

Compound 4, half-maximal inhibitory concentration: 60000 nM
The estimate for compound 4 lay 2.0-fold (0.30 log units) below the measured number; the measured number falls inside the stated range.
By their numbers in this assay, from the lowest: compound 3; then compounds 1, 2 and 4 (each within the scatter of the next).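

Going by these compounds alone, the only single-place step in this set, chloro in place of tert-butyl on an aromatic carbon, gives a 1.3-fold higher number from compound 2 to compound 4 (0.11 log units; within the scatter) in this assay. At this position the read-out does not separate the two groups, although tert-butyl has 4 heavy atoms and chloro has 1. Nothing available here offers an explanation for this result.

Going by these compounds, whether other groups on that aromatic carbon, such as an amine or a carboxylic acid, would shift the number beyond the scatter remains open. Within the data shown here, also open is which of the places in which compound 3 differs from compound 1 and compound 2 goes with its lower number; no single-place step connects it to them.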